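Phenethyl ether in a translocator protein ligand series

A few compounds are considered here, and "the series" means these few. Any claim that something is new, unique, unknown or untested is made for them only; others in the source may bear on it.

Measured compounds:
compound 1, `CCN(CC)C(=O)Cc1c(-c2ccc(OC3CCCC3)cc2)nn2c(C)cc(C)nc12`, 1.5 nM
compound 2, `CCN(CC)C(=O)Cc1c(-c2ccc(OCC3CC3)cc2)nn2c(C)cc(C)nc12`, 3 nM
compound 3, `CCN(CC)C(=O)Cc1c(-c2ccc(OCc3cccc(C(F)(F)F)c3)cc2)nn2c(C)cc(C)nc12`, 0.67 nM

The three compounds share a core and differ only in the group on the oxygen of the aromatic ring. In an assay on isolated protein (kidney, strain Wistar) for displacement of a labelled ligand from Translocator protein (Rattus norvegicus), read by scintillation counting, with a stated time of 90 min (on this read-out higher numbers stand for weaker inhibition and lower numbers for stronger inhibition), compound 3 gives the lowest of the three numbers. Its nearest neighbour is compound 1, with a 2.2-fold lower number from compound 1 to compound 3 (0.35 log units; beyond the scatter); the furthest is compound 2, with a 4.5-fold lower number from compound 2 to compound 3 (0.65 log units; beyond the scatter). Between compound 1 and compound 2 the step is a 2.0-fold higher number from compound 1 to compound 2 (0.30 log units; within the scatter).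

Compound 4, `CCN(CC)C(=O)Cc1c(-c2ccc(OCCc3ccccc3)cc2)nn2c(C)cc(C)nc12`, has not yet been measured. It differs from compound 3 in one place: benzyl in place of 3-(trifluoromethyl)phenyl on a saturated chain carbon bound to an oxygen on an aromatic ring. Among the compounds with values here, the step from compound 2 to compound 3 is the one that bears most on this change, as it shows an aromatic ring on that chain carbon giving a lower number than a cycloalkyl group; no measured step tests removing the trifluoromethyl alone. An aromatic ring is kept in compound 4, so a move back toward the numbers of compound 1 and compound 2 seems plausible but not large.

Compound 4 is therefore expected to show a 2.2-fold higher number from compound 3 to compound 4 (0.35 log units; beyond the scatter), giving an estimated 1.5 nM with a range of 0.6 nM to 4 nM.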

Compound 4, inhibition constant: 0.13 nM
Compound 4: middle estimate off by 12-fold (1.06 log units), on the high side; the measured number lies below the stated range.
By their numbers in this assay, from the lowest: compound 4; then compound 3; then compounds 1 and 2 (each within the scatter of the next).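

In this assay, the phenethyl group on the oxygen gives the lowest number of the series, with a 5.2-fold lower number from compound 3 to compound 4 (0.71 log units; beyond the scatter), so at this position an aromatic ring without trifluoromethyl, set further out along a longer chain, goes with stronger inhibition than 3-(trifluoromethyl)benzyl. Within the data shown here, the change from the non-aromatic groups is larger than any step seen among the earlier compounds: benzyl in place of cyclopropyl on the saturated chain carbon gives a 23-fold lower number from compound 2 to compound 4 (1.36 log units; beyond the scatter), and phenethyl in place of cyclopentyl on the oxygen gives a 12-fold lower number from compound 1 to compound 4 (1.06 log units; beyond the scatter). Nothing shown here bears on the reason for this result.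

The step to compound 4 removes the trifluoromethyl and lengthens the chain together, so the share of each in the change cannot be separated; an unsubstituted benzyl or a 3-(trifluoromethyl)phenethyl group on the same oxygen would divide the two. Going by these compounds, whether the trend continues with a longer chain such as 3-phenylpropyl, or whether an amine on the phenethyl ring would be accepted at this position, also remains open.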